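A few compounds are considered here, and "the series" means these few. Any claim that something is new, unique, unknown or untested is made for them only; others in the source may bear on it.

Measured so far:
compound 1 (`O=C(/C(=C\c1ccc([N+](=O)[O-])c(O)c1)SCc1ccc(Br)cc1)c1ccc([N+](=O)[O-])cc1`) gives 1000 nM in a functional assay on DU-145 cells (Homo sapiens) for inhibition, read by trypan blue exclusion, with a stated time of 96 h; on this read-out higher numbers stand for weaker inhibition of growth and lower numbers for stronger inhibition of growth
compound 2 (`O=C(O)c1ccc(C(=O)/C(=C\c2ccc(O)c([N+](=O)[O-])c2)SCc2ccc(Br)cc2)cc1`) gives 50000 nM in this assay

Of these two, compound 1 holds the lower number and so the stronger inhibition of growth, and its gap to compound 2 lies beyond the scatter. Compound 3 (`O=C(/C(=C\c1ccc([N+](=O)[O-])c(O)c1)SCc1ccc(Br)cc1)c1ccc(Br)cc1`) has not yet been measured. It differs from compound 1 in one place, with bromo in place of nitro on an aromatic carbon, para to a large group (bromo in place of nitro on an aromatic carbon). Going by the values given here, no step between measured compounds that differ in one place is available as a guide, so the expectation rests on compound 1 (1000 nM) alone. A step beyond the scatter is not expected in either direction. The estimated 1.3-fold lower number from compound 1 to compound 3 (0.10 log units; within the scatter) stays within the scatter. For compound 3 the expected value is 800 nM (estimated range 250 nM to 3000 nM).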

Compound 3, concentration for 50% growth inhibition: 10000 nM
Estimate against measurement, compound 3: 13-fold (1.10 log units) below, outside the stated range (above it).
By their numbers in this assay, from the lowest: compound 1; then compound 3; then compound 2.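

In this assay, going by these compounds alone, bromo in place of nitro on an aromatic carbon, para to a large group, brings a 10-fold higher number from compound 1 to compound 3 (1.00 log units; beyond the scatter) and so gives the first step in this set between compounds that differ in one place. It shows that this position is not indifferent to the group it carries: going from 4-nitrophenyl to 4-bromophenyl, with the rest of the core of compound 1 unchanged, weakens inhibition of growth beyond the scatter. No measurement available here accounts for this step. The compounds shown leave open how other groups on this same carbon would fare, such as a nitrile, an amine or a methoxy group. They also leave open whether removing the group altogether, leaving only hydrogen on that carbon, would give a number nearer compound 1 or compound 3.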